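The compounds below may be only part of what the source reports. "The series", "measured", "known", "first", "only" and "open" are said of these compounds alone.

Compound 2 `O=C(Nc1cccc(-c2oc3cc(-c4ccc(F)cc4)ccc3c(=O)c2O)c1)c1cnc(Cl)nc1Cl` carries a 2,4-dichloropyrimidin-5-yl group on the amide carbonyl of the shared core. In a functional assay on HepG2 cells (Homo sapiens) for antiproliferative activity, read by CCK-8 assay, with a stated time of 72 h (a lower number here means a stronger inhibitor, a higher number a weaker inhibitor), compound 2 reaches only a limit, > 100000 nM, and no number within the measured range is given. Its closest measured relative, compound 1 `O=C(Nc1cccc(-c2oc3cc(-c4ccc(F)cc4)ccc3c(=O)c2O)c1)c1ccccc1F`, differs only in bearing a 2-fluorophenyl group at the same carbonyl carbon; in this assay compound 1 gives 10100 nM. Within the data shown here, the single measured step, an at least 9.9-fold higher number from compound 1 to compound 2 (0.99 log units; beyond the scatter), is therefore a loss of activity that runs into the boundary of the assay (the limit of > 100000 nM in this assay, at which 1 of the 2 values shown sits).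

Compound 3 `O=C(Nc1cccc(-c2oc3cc(-c4ccc(F)cc4)ccc3c(=O)c2O)c1)c1ccc(-c2ccccc2)cc1` is not yet measured. It differs from compound 2 by 4-phenylphenyl in place of 2,4-dichloropyrimidin-5-yl on a carbonyl carbon. Among the measured compounds shown here, the one step that bears on this change shows that the dichloropyrimidinyl amide sits beyond the limit while a carbon-only aryl amide, compound 1, sits inside the measured range. On that basis compound 3 is expected to move back toward the level of compound 1, a step of an at least 6.6-fold lower number from compound 2 to compound 3 (0.82 log units; beyond the scatter) in this assay. Compound 3 is accordingly estimated at 15000 nM, within 4000 nM to 100000 nM.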

Compound 3, half-maximal inhibitory concentration: 88500 nM
Compound 3: middle estimate off by 5.9-fold (0.77 log units), on the low side; the measured number falls inside the stated range.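

At this carbonyl carbon, this assay records an 8.8-fold higher number from compound 1 to compound 3 (0.94 log units; beyond the scatter), so a carbon-only aryl group does not by itself hold activity near the level seen with 2-fluorophenyl. The comparison with the dichloropyrimidine amide gives an at least 1.1-fold lower number from compound 2 to compound 3 (0.05 log units; that floor lies within the scatter), so these values do not separate 4-phenylphenyl from 2,4-dichloropyrimidin-5-yl, although the true gap could be larger than this floor. Among the three amides, compound 1 alone stands apart from both others beyond the scatter, while the value of compound 2 remains a limit and not a number: the limit of > 100000 nM in this assay, at which 1 of the 3 values shown sits.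

The compounds shown leave open whether an unsubstituted phenyl ring, a pyridine ring or a short alkyl chain on the same carbonyl carbon would stay near compound 1 or fall away as compound 3 does. They also cannot tell whether the weaker result with 4-phenylphenyl follows from its second ring, from losing the fluorine of 2-fluorophenyl, or from both.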